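A benzyl group removed from an adenosine-like scaffold

The compounds below may be only part of what the source reports. "The series", "measured", "known", "first", "only" and "open" are said of these compounds alone.

Compound 1 `CCNC(=O)[C@H]1O[C@@H](n2cnc3c(NC)nc(-n4cc(CC5CCCC5)nn4)nc32)[C@H](O)[C@@H]1O` and compound 2 `COc1ccc(Cl)c(CNc2nc(-n3cc(CC4CCCC4)nn3)nc3c2ncn3[C@@H]2O[C@H](CO)[C@@H](O)[C@H]2O)c1` share a core and were tested in an assay on CHO cells for displacement of a labelled ligand from adenosine receptor A1 (Homo sapiens); on this read-out higher numbers stand for weaker inhibition and lower numbers for stronger inhibition. Compound 1 gives 1250 nM, and compound 2 gives 830 nM; the two numbers sit within the usual scatter of each other, so compound 2 stands alongside compound 1 rather than apart from it. Compound 3 `CNc1nc(-n2cc(CC3CCCC3)nn2)nc2c1ncn2[C@@H]1O[C@H](CO)[C@@H](O)[C@H]1O` differs from compound 2 by hydrogen in place of 2-chloro-5-methoxyphenyl on a saturated chain carbon bound to a nitrogen on an aromatic ring. Among the compounds with values here, no measured step of this kind is available, so the expected step from compound 2 to compound 3 is a 2.4-fold higher number from compound 2 to compound 3 (0.38 log units; beyond the scatter), a modest rise that may not exceed the scatter. Compound 3 is estimated at 2000 nM, within 600 nM to 6000 nM.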

Compound 3, inhibition constant: 335 nM
Estimate against measurement, compound 3: 6.0-fold (0.78 log units) above, outside the stated range (below it).
By their numbers in this assay, from the lowest: compound 3; then compounds 2 and 1 (each within the scatter of the next).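

In this assay, the change from (2-chloro-5-methoxybenzyl)amino to methylamino gives a 2.5-fold lower number from compound 2 to compound 3 (0.39 log units; beyond the scatter), so the substituted aromatic ring is not required for this level of inhibition. At a different place, hydroxymethyl in place of ethylcarbamoyl on a saturated ring carbon gives a 3.7-fold lower number from compound 1 to compound 3 (0.57 log units; beyond the scatter), and both steps point the same way toward compound 3. Nothing available explains either step. The compounds shown leave open how a plain amino group or an unsubstituted benzylamino group would read at the first place, and whether the ethylcarbamoyl step would hold alongside (2-chloro-5-methoxybenzyl)amino.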